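The compounds below may be only part of what the source reports. "The series", "measured", "known", "first", "only" and "open" are said of these compounds alone.

Compound 1 `Cc1cccc(Cn2cc(COc3ccc4c(=O)ccoc4c3)nn2)c1` and compound 2 `O=c1ccoc2cc(OCc3cn(Cc4cccc(Br)c4)nn3)ccc12` share one core and differ only in a group on the outer ring. In a functional assay on A549 cells (Homo sapiens) for cytotoxicity, read by MTT assay, with a stated time of 48 h (on this read-out higher numbers stand for weaker inhibition and lower numbers for stronger inhibition), compound 1 gives 20300 nM. For compound 2 this assay reports only a limit, > 100000 nM, so its true number is not known. The step of an at least 4.9-fold higher number from compound 1 to compound 2 (0.69 log units; beyond the scatter) is therefore a move toward weaker inhibition, bounded by the limit of > 100000 nM in this assay, at which 1 of the 2 values shown sits. Compound 3 `O=c1ccoc2cc(OCc3cn(Cc4cccc([N+](=O)[O-])c4)nn3)ccc12` differs from compound 2 by nitro in place of bromo on an aromatic carbon. Going by the values given here, no measured step exchanges bromo for nitro, so the only guidance is the single measured step, which leaves the bromo compound at the edge of what this assay can measure. Nothing in the numbers points back toward stronger inhibition, and compound 2 sits at the limit already. For compound 3 the step of a number no higher from compound 2 to compound 3 (the limit leaves the size open) is expected, meaning it is expected to stay near that limit and may again be reported only as a limit. Compound 3 is estimated at 100000 nM in this assay, within a range from 30000 nM to 300000 nM.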

Compound 3, half-maximal inhibitory concentration: 9450 nM
The estimate for compound 3 lay 11-fold (1.02 log units) above the measured number; the whole stated range lies above it.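

The earlier pair showed only a move toward weaker inhibition at this place on the outer ring, and the new result shows that the same place can also move toward stronger inhibition. In this assay, replacing the 3-bromophenyl group with the 3-nitrophenyl group gives an at least 10-fold lower number from compound 2 to compound 3 (1.02 log units; beyond the scatter), a size that is only a lower bound, since the value of compound 2 is a limit: the limit of > 100000 nM in this assay, at which 1 of the 3 values shown sits. Nitro also improves on methyl in the same place, with a 2.1-fold lower number from compound 1 to compound 3 (0.33 log units; beyond the scatter), so compound 3 has the strongest inhibition of the three and the group at this one place can set the result in either direction, from nitro through methyl to bromo.

These three compounds give no reason for the order, and a group such as an amine, a carboxylic acid or a methoxy in the same place could fall anywhere relative to nitro, methyl and bromo. From the compounds shown here alone, whether nitro would keep its lead at another place on the ring, or on cells other than the ones used here, also remains open.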